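The compounds below may be only part of what the source reports. "The series", "measured", "known", "first", "only" and "open" are said of these compounds alone.

Working notes on the series in a functional assay on MOLT-4 cells (Homo sapiens); on this read-out higher numbers stand for weaker inhibition and lower numbers for stronger inhibition.

Of the compounds shown here, three carry numbers so far. Compound 1 `O=C(/C=C/c1ccc(F)cc1)Oc1ccc(/C=C2\CCCCC2=O)cc1` gives 26600 nM. Compound 2 `CN(C)CC1CCC/C(=C\c2ccc(OC(=O)/C=C/c3ccccc3)cc2)C1=O` gives 39500 nM. Compound 3 `Cc1ccc(/C=C/C(=O)Oc2ccc(/C=C3\CCCC(CN(C)C)C3=O)cc2)cc1` gives 3390 nM, the lowest number of the three; the nearest is compound 1 and the furthest is compound 2, both well beyond the scatter. Within the data shown here, the one single-point step measured, a 12-fold lower number from compound 2 to compound 3 (1.07 log units; beyond the scatter), is the only one that bears on the aromatic position now in question, and it was large.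

Compound 4 `CN(C)CC1CCC/C(=C\c2ccc(OC(=O)/C=C/c3ccc(F)cc3)cc2)C1=O` differs from compound 3 in one place: fluoro in place of methyl on an aromatic carbon. Among the measured compounds shown here, no measured pair shows fluoro against methyl directly. For the measured compounds named here, what is known of the fluoro group comes only from compound 1, whose value of 26600 nM sits near that of compound 2 at 39500 nM, though those two differ in two places and give no clean step. Against that, the methyl in compound 3 brought the large drop recorded in a 12-fold lower number from compound 2 to compound 3 (1.07 log units; beyond the scatter). The expectation is that fluoro does not reproduce the full gain of methyl, so the number for compound 4 is expected to rise, by a 3.5-fold higher number from compound 3 to compound 4 (0.55 log units; beyond the scatter), to an estimated 12000 nM, within a range of 4000 nM to 35000 nM.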

Compound 4, half-maximal inhibitory concentration: 3780 nM
The estimate for compound 4 lay 3.2-fold (0.50 log units) above the measured number; measured number below the stated range.
By their numbers in this assay, from the lowest: compounds 3 and 4 (each within the scatter of the next); then compounds 1 and 2 (each within the scatter of the next).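

In this assay the step of a 1.1-fold higher number from compound 3 to compound 4 (0.05 log units; within the scatter) leaves fluoro and methyl on this aromatic carbon level with each other, so the large drop seen with methyl is not particular to that group. Fluoro in place of hydrogen gives a large step of its own in a 10-fold lower number from compound 2 to compound 4 (1.02 log units; beyond the scatter) and stands alongside a 12-fold lower number from compound 2 to compound 3 (1.07 log units; beyond the scatter) as a second case of a substituent at this place, while a 7.0-fold lower number from compound 1 to compound 4 (0.85 log units; beyond the scatter) gives the first clean reading of (dimethylamino)methyl on the saturated ring carbon with the 4-fluorophenyl group held constant, and that step is modest. No evidence on hand speaks to the reason for any of these steps.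

The compounds shown leave open whether a chloro, methoxy or amino group on this aromatic carbon would also match fluoro and methyl, since only these two substituents can be compared with hydrogen here. They also leave open whether methyl would bring a comparable step in a compound without (dimethylamino)methyl, and whether a pyrrolidine or morpholine in place of the dimethylamino group would keep the number seen with compound 4.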